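Lengthening the ring-nitrogen substituent from hydrogen to pentyl

The source may report more compounds than this note shows. Statements on the series, on what has been measured and on what is new or still open speak of the compounds shown alone.

Compound 1 `COC1Cc2c(cnn2-c2ccccc2)C2(CCNCC2)O1` carries a bare amine nitrogen in a ring. In an assay for displacement of a labelled ligand from Sigma non-opioid intracellular receptor 1 (Cavia porcellus), read by scintillation counting, with a stated time of 180 min (on this read-out higher numbers stand for weaker inhibition and lower numbers for stronger inhibition), compound 1 gives > 1000 nM, which is a limit of the assay rather than a number (the limit of > 1000 nM in this assay, at which 1 of the 3 values shown sits). Compound 2 `COC1Cc2c(cnn2-c2ccccc2)C2(CCN(Cc3ccco3)CC2)O1` gives 2.2 nM in this assay, and compound 3 `CCCCN1CCC2(CC1)OC(OC)Cc1c2cnn1-c1ccccc1` gives 8 nM. Two measured steps set out from compound 1: an at least 450-fold lower number from compound 1 to compound 2 (2.65 log units; beyond the scatter), and an at least 120-fold lower number from compound 1 to compound 3 (2.09 log units; beyond the scatter). Between the two substituted compounds the step is smaller: a 3.6-fold higher number from compound 2 to compound 3 (0.56 log units; beyond the scatter).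

Compound 4 `CCCCCN1CCC2(CC1)OC(OC)Cc1c2cnn1-c1ccccc1` differs from compound 1 in one place: pentyl in place of hydrogen on an amine nitrogen in a ring. Both steps from compound 1 bear on this change, as each replaces the same hydrogen on the amine nitrogen in a ring with a carbon-based group, and each is large. Compound 3, with its butyl group, is the nearest measured match to the pentyl chain of compound 4, so a step of about that size, in the direction of a lower number, is expected here. The expected step is an at least 160-fold lower number from compound 1 to compound 4 (2.22 log units; beyond the scatter). Compound 4 is therefore estimated at 6 nM in this assay, with a likely range from 2 nM to 20 nM.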

Compound 4, inhibition constant: 0.82 nM
Estimate against measurement, compound 4: 7.3-fold (0.86 log units) above; the measured number lies below the stated range.
By their numbers in this assay, from the lowest: compound 4; then compound 2; then compound 3. At a limit, above all of these: compound 1.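

Going from butyl to pentyl on the amine nitrogen gives a 9.8-fold lower number from compound 3 to compound 4 (0.99 log units; beyond the scatter) in this assay, so the length of the straight chain matters here, and not only the presence of a chain. Pentyl also gives a 2.7-fold lower number from compound 2 to compound 4 (0.43 log units; beyond the scatter), so a plain chain with no ring at its end can give the lowest number of this set, although compound 3, with its butyl chain, stays on the weaker side of compound 2. The full change from hydrogen to pentyl reads an at least 1200-fold lower number from compound 1 to compound 4 (3.08 log units; beyond the scatter), and that size is only a lower bound because compound 1 stands at a limit of the assay and not at a number: the limit of > 1000 nM in this assay, at which 1 of the 4 values shown sits.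

As far as these compounds go, whether the number keeps falling with a longer chain, such as hexyl or heptyl, or turns back up remains open, as does the effect of shorter chains, such as methyl or ethyl. The compounds shown also leave open how benzyl, with a phenyl ring in the place of the furan-2-yl of compound 2, would compare.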